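A few compounds are considered here, and "the series" means these few. Any claim that something is new, unique, unknown or untested is made for them only; others in the source may bear on it.

Compound 2 `COc1ccc(-c2cc(=O)c3c(OC)cc(OC)cc3n2S(=O)(=O)c2ccc(F)cc2)cc1` gives in a functional assay on KOPN-8 cells (Homo sapiens) for antiproliferative activity, with a stated time of 72 h (a higher number here means that more compound is needed for the effect, a lower number that less compound is needed), only a limit, > 65500 nM. Compound 1 `COc1ccc(-c2cc(=O)c3c(OC)cc(OC)cc3n2S(=O)(=O)c2ccc(C)c([N+](=O)[O-])c2)cc1` likewise gives in this assay only a limit, > 51700 nM. The step between them, a step that the two limits leave unreadable from compound 1 to compound 2, cannot be read, because both of its ends are limits the limit of > 51700 nM in this assay, at which 1 of the 2 values shown sits (the limit of > 65500 nM in this assay, at which 1 of the 2 values shown sits). Compound 3 `COc1ccc(-c2cc(=O)c3c(OC)cc(OC)cc3n2S(=O)(=O)c2c(F)c(F)c(F)c(F)c2F)cc1` differs from compound 2 by 2,3,4,5,6-pentafluorophenyl in place of 4-fluorophenyl on a sulfonyl sulfur. No readable step bears on this change, and the shared core has shown no measurable activity in this assay so far. Compound 3 is therefore expected to remain near the limit, with an estimated step of an at least 1.0-fold lower number from compound 2 to compound 3 (0.03 log units; that floor lies within the scatter). The estimate for compound 3 is 60000 nM, from 20000 nM to 200000 nM.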

Compound 3, half-maximal effective concentration: > 34400 nM
Compound 3 gave a limit, no number; the forecaster's own chance of this, stated with the estimate: 80%; the middle value is on the limit's open side.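

Compound 3 gives only a limit, > 34400 nM, so its steps from compound 1 and compound 2 cannot be read. The compounds shown leave open whether any group on the sulfonyl sulfur gives a measurable value in this assay.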